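Cell Toxicity of Two Amines and a Proposed Third

This account rests on a few compounds, and the source may have more. Where it says the series, first, only, none or still open, it means among the compounds named here.

compound 1 `CCCCC(c1cc2ccc(C)cc2[nH]c1=O)N(Cc1ccc(F)cc1)Cc1ccc(C(C)C)cc1`: in a toxicity assay on MDCK cells (Canis lupus familiaris) for cytotoxicity, read by crystal violet staining, with a stated time of 48 h (on this read-out lower numbers stand for higher toxicity in this test and higher numbers for lower toxicity in this test), compound 1 gives > 33000 nM, a limit.
compound 2 `CCOc1ccc(CN(Cc2ccc(C(C)(C)C)cc2)Cc2cc3cc(C)ccc3[nH]c2=O)cc1`: in this assay compound 2 gives > 10000 nM, also a limit.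

Compound 2 thus shows only a limit in this assay, the one recorded as the limit of > 10000 nM in this assay, at which 1 of the 2 values shown sits. Compound 1 likewise shows only a limit, recorded as the limit of > 33000 nM in this assay, at which 1 of the 2 values shown sits. Compound 3 `COc1ccc(C(C)N(Cc2ccc(C(C)(C)C)cc2)Cc2cc3cc(C)ccc3[nH]c2=O)cc1Cl` differs from compound 2 in one place: 1-(3-chloro-4-methoxyphenyl)ethyl in place of 4-ethoxybenzyl on an amine nitrogen. Going by the values given here, no measured step exists for a change of this kind, so the expected step that the limit leaves unreadable from compound 2 to compound 3 in this assay is taken to stay within the scatter. Compound 3 is therefore estimated at 20000 nM, within 8000 nM to 60000 nM.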

Compound 3, half-maximal cytotoxic concentration: > 10000 nM
Compound 3: a limit, no number; the forecaster's own chance of this, stated with the estimate: 75%; the middle value lies beyond the limit too.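

Going by these compounds alone, compound 2 and compound 3 each give only a limit in this assay, and no step between them can be read. The compounds shown leave open whether 1-(3-chloro-4-methoxyphenyl)ethyl in place of 4-ethoxybenzyl changes cell toxicity at all.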